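Indole in place of isoquinoline on the carbonyl carbon

The compounds below may be only part of what the source reports. "The series", "measured", "known", "first", "only" and "open" are said of these compounds alone.

Compound 3 `N=C(N)NCCC[C@@H](NC(=O)c1cc2ccccc2cn1)C(=O)NCc1ccc(C(F)(F)F)cc1` gives 1810 nM in a functional assay on HEK293 cells for antagonist activity at melanin-concentrating hormone receptor 1 (Homo sapiens) (on this read-out lower numbers stand for stronger inhibition and higher numbers for weaker inhibition), the highest of the three numbers. Compound 1 `N=C(N)NCCC[C@@H](NC(=O)c1cnc2ccccc2c1)C(=O)NCc1ccc(C(F)(F)F)cc1` gives 96 nM, and compound 2 `COc1ccc2[nH]c(C(=O)N[C@H](CCCNC(=N)N)C(=O)NCc3ccc(C(F)(F)F)cc3)cc2c1` gives 78 nM. Compound 4 `N=C(N)NCCC[C@@H](NC(=O)c1cc2cc(F)ccc2[nH]1)C(=O)NCc1ccc(C(F)(F)F)cc1` differs from compound 3 by 5-fluoro-1H-indol-2-yl in place of isoquinolin-3-yl on a carbonyl carbon. Among the compounds with values here, two steps bear on this: a 19-fold higher number from compound 1 to compound 3 (1.28 log units; beyond the scatter) and, closer in kind because an indole is exchanged, a 23-fold higher number from compound 2 to compound 3 (1.37 log units; beyond the scatter). Reversing that kind of exchange is therefore expected to bring a large decrease, with the step of an 18-fold lower number from compound 3 to compound 4 (1.26 log units; beyond the scatter) estimated for compound 4 in this assay. Compound 4 is thus expected to give about 100 nM, with a range from 40 nM to 300 nM.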

Compound 4, half-maximal inhibitory concentration: 25 nM
Compound 4: middle estimate off by 4.0-fold (0.60 log units), on the high side; the measured number lies below the stated range.
By their numbers in this assay, from the lowest: compound 4; then compounds 2 and 1 (each within the scatter of the next); then compound 3.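

In this assay, replacing isoquinolin-3-yl with 5-fluoro-1H-indol-2-yl on the carbonyl carbon gives a 72-fold lower number from compound 3 to compound 4 (1.86 log units; beyond the scatter) here, so this position tolerates large swings. Compound 1 and compound 2 had stood within the scatter of each other, but this result separates the groups: fluoro in place of methoxy on an aromatic carbon gives a 3.1-fold lower number from compound 2 to compound 4 (0.49 log units; beyond the scatter) and 5-fluoro-1H-indol-2-yl in place of quinolin-3-yl gives a 3.8-fold lower number from compound 1 to compound 4 (0.58 log units; beyond the scatter) at this site. Going by these compounds, whether chloro or a nitrile on that aromatic carbon would match fluoro remains open. Nothing offered here accounts for these steps.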